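A few compounds are considered here, and "the series" means these few. Any claim that something is new, unique, unknown or untested is made for them only; others in the source may bear on it.

Measured compounds and their numbers:
compound 1 `O=C(/C=C/c1ccc(B(O)O)cc1)c1ccc[nH]1` — 19000 nM
compound 2 `O=C(O)COc1ccc(/C=C/C(=O)c2ccc(Cl)c(Cl)c2)cc1` — 15000 nM
compound 3 `O=C(/C=C/c1ccc(B(O)O)cc1)c1ccc(Cl)c(Cl)c1` — 5500 nM

All three were tested in a functional assay on MCF7 cells (Homo sapiens) for inhibition; a lower number here means a stronger inhibitor, a higher number a weaker inhibitor. Compound 1 stands at the highest number of the three; compound 2 sits within the scatter of it, while compound 3 lies beyond the scatter at a lower number. Going by the values given here, the only single-point step among the measured compounds is a 2.7-fold lower number from compound 2 to compound 3 (0.44 log units; beyond the scatter), in which a boronic acid took the place of a larger group on an aromatic carbon, a modest move toward stronger inhibition.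

Compound 4 `O=C(/C=C/c1ccccc1)c1ccc[nH]1` has not yet been measured. It differs from compound 1 by a hydrogen atom in place of a group of 3 heavy atoms (1 boron, 2 oxygen; no ring), on an aromatic carbon, on an aromatic carbon of a six-membered aromatic ring of carbon only. Among the compounds with values here, no measured step removes a boronic acid outright, so the change is only indirectly informed. Because a 2.7-fold lower number from compound 2 to compound 3 (0.44 log units; beyond the scatter) shows the number falling when the boronic acid entered, its removal in compound 4 is expected to move the number the other way, by a modest amount that may not clear the scatter: a 1.6-fold higher number from compound 1 to compound 4 (0.20 log units; within the scatter). For compound 4 the estimate is 30000 nM, with a range from 10000 nM to 90000 nM.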

Compound 4, half-maximal inhibitory concentration: 9000 nM
Beside the measured number, compound 4's estimate is 3.3-fold (0.52 log units) above it; the whole stated range lies above it.
By their numbers in this assay, from the lowest: compounds 3, 4, 2 and 1 (each within the scatter of the next, the first and the last beyond it).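

Read in this assay, the result shows that the boronic acid on an aromatic carbon of a six-membered aromatic ring of carbon only is not needed for inhibition on the core of compound 1, since replacing it with a hydrogen atom gives a 2.1-fold lower number from compound 1 to compound 4 (0.32 log units; beyond the scatter) and so a modest gain rather than a loss. The earlier step, a 2.7-fold lower number from compound 2 to compound 3 (0.44 log units; beyond the scatter), had the number fall as the boronic acid entered on a different core, so the two steps run in opposite directions and no single effect of the boronic acid can be read across both cores. Nothing measured here explains why the two cores differ in this way.

Going by these compounds, what remains open is whether the number on the core of compound 1 would move further with another small group in the same place, such as a fluorine atom, a methoxy group or an amine. Also open, on these data alone, is whether taking the boronic acid off compound 3 would raise the number or lower it, which would show whether the opposite directions truly belong to the two cores.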